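A few compounds are considered here, and "the series" means these few. Any claim that something is new, unique, unknown or untested is made for them only; others in the source may bear on it.

Measured compounds in a functional assay on the whole organism (strain CD-1) with Mus musculus as the target, in the maximal electroshock model, with a stated time of 2 h; on this read-out lower numbers stand for an effect already at smaller amounts and higher numbers for an effect only at larger amounts of compound:

compound 1 `CC1(c2ccccc2)CC(=O)N(CC(=O)N2CCN(c3ccccc3Cl)CC2)C1=O`: "not active" (no number reported)
compound 2 `CC1(c2ccccc2)CC(=O)N(CC(=O)N2CCN(c3cccc(C(F)(F)F)c3)CC2)C1=O`: 300 mg/kg
compound 3 `Cc1cccc(N2CCN(C(=O)CN3C(=O)CC(C)(c4ccccc4)C3=O)CC2)c1`: 300 mg/kg

Compound 1 stands apart from the others on the numbers shown: in this assay compound 1 is recorded as "not active" (no number reported), and no dose is given, so it has no place on the scale on which compounds 2 and 3 sit. Compound 4 `COc1cccc(N2CCN(C(=O)CN3C(=O)CC(C)(c4ccccc4)C3=O)CC2)c1` remains to be measured. It differs from compound 1 by 3-methoxyphenyl in place of 2-chlorophenyl on an amine nitrogen in a ring.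

For the measured compounds named here, no measured step reproduces this change. Going by the values given here, the only step on record, no change at the digits printed from compound 2 to compound 3 (within the scatter), exchanges one group for another on the aromatic ring and leaves the read-out where it was. It shows that among the two measured aryl groups that carry their substituent at the same position, the dose did not move, and compound 4 carries its methoxy group in that same relative arrangement. The shift from compound 1 is not quantifiable, since compound 1 gave no number; a return to the range of compounds 2 and 3 is the plain expectation, with a real chance that no activity is seen again.

For compound 4 the expected value in this assay is 300 mg/kg, with a range from 100 mg/kg to 600 mg/kg.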

Compound 4, minimum effective dose: "not active" (no number reported)
Compound 4 has no reported number here, so the estimate cannot be set against anything.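

Compound 1 and compound 4 both carry no number in this assay, so no step can be read between them. Going by these compounds, whether 2-chlorophenyl and 3-methoxyphenyl differ at all on this read-out stays open. Nothing measured here accounts for the missing activity of compound 4.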